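The source may report more compounds than this note shows. Statements on the series, on what has been measured and on what is new or still open speak of the compounds shown alone.

Compound 1 `COc1cc(C)cc(-c2c(-c3ccnc(-c4ccc(C(C)=O)cc4)c3)cnn2CC#N)c1` gives 69% in a functional assay on HOP-92 cells (Homo sapiens) for cytotoxicity, read by sulforhodamine B assay, with a stated time of 48 h, tested at 0.01 uM; a higher number here means a weaker effect of the compound at the concentration tested, a lower number a stronger effect. Compound 2 `COc1cc(C)cc(-c2nn(CC#N)cc2-c2ccnc(-c3ccc(N(C)C)cc3)c2)c1` gives 93% in this assay; compound 1 thus holds the lower of the two numbers, and its gap to compound 2 lies beyond the usual scatter. Compound 3 `COc1cc(C)cc(-c2c(-c3ccnc(-c4ccc(N(C)C)cc4)c3)cnn2CC#N)c1` is the unmeasured analogue of compound 1, differing by dimethylamino in place of acetyl on an aromatic carbon. For the measured compounds named here, no measured pair shows this exact change. Compound 2 carries the same dimethylamino group and gives 93%, so a rise in the number is expected for this change. The expected step is a number 16 percentage points higher from compound 1 to compound 3 (beyond the scatter) in this assay. Compound 3 is estimated at 85%, within 70% to 100%.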

Compound 3, a percentage reported as activity, at one concentration (the size of the read-out at that concentration, not a potency): -9%
The estimate for compound 3 lay 94 percentage points above the measured number; measured number below the stated range.
By their numbers in this assay, from the lowest: compound 3; then compound 1; then compound 2.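

In this assay dimethylamino in place of acetyl on an aromatic carbon, para to a large group, gives a number 78 percentage points lower from compound 1 to compound 3 (beyond the scatter) and so marks this position as highly sensitive to the group it carries. The two groups count the same heavy atoms and hydrogen-bond acceptors, so those counts do not follow the read-out across this pair. Nothing available bears on the cause of this step.

As far as these compounds go, whether a primary amine, a carboxylic acid or a longer chain at this position would sit nearer compound 1 or compound 3 stays open. With one concentration only, the read-out shows the stronger effect of compound 3 at that concentration and no more.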